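The source may hold more compounds than are shown below. What is called first, only, known or untested is meant among the compounds shown, and "the series" means these compounds.

Series notes. Compound 1 `Oc1ccc2c(c1)CCc1ccc(O)c(c1)Oc1ccc(cc1)CCc1cccc(O)c1O2` is the parent; in a functional assay on K562 cells (Homo sapiens) for antiproliferative activity, read by MTT assay, with a stated time of 48 h (a higher number here means a weaker inhibitor, a lower number a stronger inhibitor), compound 1 gives 14100 nM. Compound 2 `Oc1cc2c(cc1O)Oc1c(O)cccc1CCc1ccc(cc1)Oc1cc(ccc1O)CC2` carries one extra group, (hydroxy in place of hydrogen on an aromatic carbon), and in this assay compound 2 gives 6160 nM, so that a 2.3-fold lower number from compound 1 to compound 2 (0.36 log units; beyond the scatter). Compound 3 `Oc1ccc2cc1Oc1ccc(cc1)CCc1ccc(O)c(c1)Oc1ccc(cc1)CC2` rests on a second core; the difference between the two cores is not broken down here. In this assay compound 3 gives 10300 nM, within the scatter of both compound 1 and compound 2. Compound 4 `Oc1ccc2cc1Oc1ccc(cc1)CCc1ccc(O)c(c1)Oc1ccc(cc1O)CC2` is unmeasured and takes the same kind of change from compound 3, (hydroxy in place of hydrogen on an aromatic carbon). The surroundings differ: in compound 2 the group is ortho to a hydroxy group, meta to a fused ring and para to a fused ring, in compound 4 ortho to a fused ring and meta to a fused ring. Set beside the earlier step, a smaller step is expected for compound 4, a 1.7-fold lower number from compound 3 to compound 4 (0.23 log units; within the scatter), because the single precedent a 2.3-fold lower number from compound 1 to compound 2 (0.36 log units; beyond the scatter) comes from a differently placed group. Compound 4 is estimated at 6000 nM, between 3000 nM and 12000 nM.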

Compound 4, half-maximal inhibitory concentration: 15600 nM
Compound 4: middle estimate off by 2.6-fold (0.41 log units), on the low side, and the stated range ends below it.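

In this assay the hydroxy change does not carry over unchanged between these two cores: the same change on two cores in this assay, a 2.3-fold lower number (0.36 log units; beyond the scatter) from compound 1 to compound 2 and a 1.5-fold higher number (0.18 log units; within the scatter) from compound 3 to compound 4, 3.5-fold (0.54 log units) apart, beyond the scatter of two such steps. The new step, a 1.5-fold higher number from compound 3 to compound 4 (0.18 log units; within the scatter), leaves compound 4 within the scatter of compound 3, so the modest gain on the core of compound 1 does not reappear on the core of compound 3. The added hydroxy also sits in a different place on each core, and a single pair per core cannot separate the effect of the core from that of placement.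

Still open, going by these compounds, is whether hydroxy placed identically on both cores would give matching steps. Also open, on these data alone, is how a methoxy group or an amine at these places would compare with hydroxy.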